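Replacing a Pyridine Ring with a Methylated Phenyl Ring

The source may report more compounds than this note shows. Statements on the series, on what has been measured and on what is new or still open speak of the compounds shown alone.

Compound 2 `CC(C)OC(=O)N1CCC(Oc2ncnc3c2CCN3c2ccc(S(C)(=O)=O)nc2)CC1` gives 251 nM in a functional assay on CHO-K1 cells for agonist activity at Glucose-dependent insulinotropic receptor (Homo sapiens), read by a luciferase reporter, with a stated time of 5 h (a lower number here means that less compound is needed, a higher number that more compound is needed for the effect), the lowest of the two numbers measured, although compound 1 `CC(C)OC(=O)N1CCC(Oc2cccc3c2CCN3c2ccc(S(C)(=O)=O)cc2)CC1` with 501 nM lies within the scatter of it. Compound 3 `Cc1cc(S(C)(=O)=O)ccc1N1CCc2c(OC3CCN(C(=O)OC(C)C)CC3)ncnc21` has not yet been measured. It differs from compound 2 in one place: 2-methyl-4-(methylsulfonyl)phenyl in place of 6-(methylsulfonyl)pyridin-3-yl on a nitrogen on an aromatic ring in a ring. For the measured compounds named here, no measured pair shows this exact change, so the step is uncertain. A step of a 1.4-fold lower number from compound 2 to compound 3 (0.14 log units; within the scatter) is expected, barely beyond the scatter and toward a lower number. Compound 3 is therefore estimated at 180 nM in this assay, with a likely range from 60 nM to 600 nM.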

Compound 3, half-maximal effective concentration: 100 nM
Beside the measured number, compound 3's estimate is 1.8-fold (0.26 log units) above it, within the range that was stated.
By their numbers in this assay, from the lowest: compound 3; then compounds 2 and 1 (each within the scatter of the next).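

In this assay the change to 2-methyl-4-(methylsulfonyl)phenyl gives a 2.5-fold lower number from compound 2 to compound 3 (0.40 log units; beyond the scatter) at the nitrogen of the five-membered non-aromatic ring, so the group at this position can move the number beyond the scatter. The change removes the ring nitrogen and adds a methyl at once, so the step cannot be divided between them. No measured property is available to explain the step.

From the compounds shown here alone, whether the methyl or the loss of the ring nitrogen matters more remains open. So does the effect of an ethyl group or an amine in place of that methyl.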